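A Sulfur for Oxygen Swap on the Shared Core

This account rests on a few compounds, and the source may have more. Where it says the series, first, only, none or still open, it means among the compounds named here.

Measured so far:
compound 1, `COc1nonc1/C(=N/O)Nc1ccc(F)c(Br)c1`: 39 nM
compound 2, `N#Cc1cccc(N/C(=N\O)c2nonc2SCCNC(=O)CS(N)(=O)=O)c1`: 44 nM

In an assay for inhibition of Indoleamine 2,3-dioxygenase 1 (Homo sapiens), read by fluorescence, with a stated time of 24 h (on this read-out lower numbers stand for stronger inhibition and higher numbers for weaker inhibition), compound 1 gives 39 nM. In this assay compound 2 gives 44 nM. These two numbers lie within the usual scatter of each other, so compound 1 cannot be set apart from compound 2 on this read-out.

Compound 3, `CSc1nonc1/C(=N/O)Nc1ccc(F)c(Br)c1`, has not yet been measured. It differs from compound 1 in one place: methylsulfanyl in place of methoxy on an aromatic carbon. Among the measured compounds shown here, no pair of measured compounds shows the effect of this exchange directly. Compound 2 does carry a group joined through sulfur on the shared core and gives 44 nM, which sits close to the number of compound 1. On that ground a step of no more than the scatter is expected. The expected step is a 1.2-fold higher number from compound 1 to compound 3 (0.06 log units; within the scatter), in no clear direction. Compound 3 is expected to give about 45 nM, within a range from 15 nM to 140 nM.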

Compound 3, half-maximal inhibitory concentration: 15 nM
Compound 3: the middle estimate sits 3.0-fold (0.48 log units) above what was measured; the range from low to high includes it.
By their numbers in this assay, from the lowest: compound 3; then compounds 1 and 2 (each within the scatter of the next).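

In this assay, methylsulfanyl in place of methoxy on an aromatic carbon of the shared core gives a 2.6-fold lower number from compound 1 to compound 3 (0.41 log units; beyond the scatter), a modest step beyond the scatter. Among the compounds shown here, this is the first direct reading of the exchange, and it shows that this position responds to a change of a single atom: the two groups have the same counts of heavy atoms, hydrogen-bond donors and acceptors, and neither carries a net charge. No measurement at hand bears on why the sulfur-linked group gives the lower number.

The compounds shown leave open whether a longer chain on the sulfur, such as ethylsulfanyl, or an amine at this same place would keep, extend or lose the step. They also leave open whether the exchange gives a similar step when the rest of the molecule differs from compound 1.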